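Pyrimidinyl in place of fluorophenyl on a piperazine amide

The compounds below may be only part of what the source reports. "The series", "measured", "known", "first", "only" and "open" are said of these compounds alone.

Measured compounds:
compound 1 `CC1(c2ccccc2)CC(=O)N(CC(=O)N2CCN(c3ccccc3F)CC2)C1=O`: 100 mg/kg
compound 2 `CC1(c2ccccc2)CC(=O)N(CC(=O)N2CCN(c3ccc(Cl)cc3)CC2)C1=O`: "not active" (no number reported)
compound 3 `CC1(c2ccccc2)CC(=O)N(CC(=O)N2CCN(c3cccc(Cl)c3Cl)CC2)C1=O`: "not active" (no number reported)

Within the data shown here, in a functional assay on the whole organism (strain CD-1) with Mus musculus as the target, in the maximal electroshock model, with a stated time of 0.5 h (on this read-out higher numbers stand for an effect only at larger amounts of compound and lower numbers for an effect already at smaller amounts), compound 1 gives 100 mg/kg and is the only compound with a number; compound 2 is recorded as "not active" (no number reported) and compound 3 as "not active" (no number reported), both without a number. Among the measured compounds shown here, no step between measured compounds is available, so the change to compound 4 `CC1(c2ccccc2)CC(=O)N(CC(=O)N2CCN(c3ncccn3)CC2)C1=O` rests on compound 1 alone. The change is pyrimidin-2-yl in place of 2-fluorophenyl on an amine nitrogen in a ring. With two aryl variants giving no activity, the expected step from compound 1 to compound 4 is no change at the digits printed from compound 1 to compound 4 (within the scatter), with no real direction beyond the scatter. Compound 4 is thus expected at 100 mg/kg in this assay, within a range from 50 mg/kg to 300 mg/kg, with a sizeable chance of no activity at all.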

Compound 4, minimum effective dose: "not active" (no number reported)
Compound 4 has no reported number here; no gap can be computed for the estimate.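

In this assay, among these compounds, compound 4 gives "not active" (no number reported), so no step from compound 1 to compound 4 can be read. The compounds shown leave open how far pyrimidin-2-yl and 2-fluorophenyl differ, since only compound 1 carries a number. Nothing measured here bears on the cause of this result.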